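Series notes: trifluoromethoxy in place of methyl

This account rests on a few compounds, and the source may have more. Where it says the series, first, only, none or still open, it means among the compounds named here.

Measured so far in a functional assay on KBVIN cells (Homo sapiens) for antiproliferative activity, read by sulforhodamine B assay, with a stated time of 72 h; a lower number here means a stronger inhibitor of growth, a higher number a weaker inhibitor of growth:
compound 1 `Cc1cc(=O)oc2cc(SCc3cccc(C(F)(F)F)c3)ccc12` — > 28500 nM, a limit of the assay
compound 2 `COC(=O)c1cccc(CSc2ccc3c(C)cc(=O)oc3c2)c1` — 5410 nM
compound 3 `Cc1cccc(CSc2ccc3c(C)cc(=O)oc3c2)c1` — > 33700 nM, a limit of the assay

Compound 3 stands at a limit in this assay, with the step of an at least 6.2-fold higher number from compound 2 to compound 3 (0.79 log units; beyond the scatter) beyond the scatter, whereas the step that the two limits leave unreadable from compound 1 to compound 3 cannot be read between two limits the limit of > 28500 nM in this assay, at which 1 of the 3 values shown sits (the limit of > 33700 nM in this assay, at which 1 of the 3 values shown sits). Compound 4 `Cc1cc(=O)oc2cc(SCc3cccc(OC(F)(F)F)c3)ccc12` carries trifluoromethoxy in place of methyl on an aromatic carbon. The step from compound 1 to compound 3 is the one that bears on this change, and its size is unreadable. Compound 1 likewise sits at a limit. No step beyond the scatter is therefore expected in this assay. Compound 4 is expected to give 30000 nM (range 8000 nM to 100000 nM), which would mean an at least 1.1-fold lower number from compound 3 to compound 4 (0.05 log units; that floor lies within the scatter).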

Compound 4, concentration for 50% growth inhibition: 15300 nM
For compound 4 the middle estimate is 2.0-fold (0.29 log units) above the measured one; measured number inside the range.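

Trifluoromethoxy on this aromatic carbon gives a readable number in this assay, where methyl and trifluoromethyl gave only limits of the assay (an at least 2.2-fold lower number from compound 3 to compound 4 (0.34 log units; beyond the scatter)). Against trifluoromethyl only a floor can be read, and it lies within the scatter (an at least 1.8-fold lower number from compound 1 to compound 4 (0.27 log units; that floor lies within the scatter)), so these two groups cannot be ordered. Methoxycarbonyl keeps the lower number (a 2.8-fold higher number from compound 2 to compound 4 (0.45 log units; beyond the scatter)), so a second group besides it now gives a readable number at this position.

On these data alone, what separates these groups remains open. A carboxylic acid or an amine on the same aromatic carbon would show whether any group gives a lower number than methoxycarbonyl.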